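Furanylmethyl for methylbenzyl on the amino arm

A few compounds are considered here, and "the series" means these few. Any claim that something is new, unique, unknown or untested is made for them only; others in the source may bear on it.

The series shares the core of compound 1 `CNc1nc(/C=C/c2cc(OC)c(OC)c(OC)c2)nc2ccsc12`, which in a functional assay on L02 cells (Homo sapiens) for inhibition, read by Griess assay, with stated times of 1 h and 24 h (a lower number here means a stronger inhibitor, a higher number a weaker inhibitor), gives a value that is only a limit of the assay, > 1000000 nM. Compound 2 `COc1cc(/C=C/c2nc(N3CCCC3)c3sccc3n2)cc(OC)c1OC` gives 681000 nM in this assay. Compound 3 `COc1cc(/C=C/c2nc(NCc3ccc(C)cc3)c3sccc3n2)cc(OC)c1OC` in this assay likewise gives only a limit of the assay, > 1000000 nM. Compound 3 thus stands where no number, only a limit, is known, and (the limit of > 1000000 nM in this assay, at which 2 of the 3 values shown sit). Among the measured compounds shown here, the step that the two limits leave unreadable from compound 1 to compound 3 cannot be read, and an at least 1.4-fold higher number from compound 2 to compound 3 (0.16 log units; that floor lies within the scatter) is only a floor; the one readable comparison in the set, an at least 1.4-fold lower number from compound 1 to compound 2 (0.16 log units; that floor lies within the scatter), touches a different position.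

Compound 4 `COc1cc(/C=C/c2nc(NCc3ccco3)c3sccc3n2)cc(OC)c1OC` differs from compound 3 as follows: furan-2-yl in place of 4-methylphenyl on a saturated chain carbon bound to a nitrogen on an aromatic ring. For the measured compounds named here, no measured step exchanges one aryl group for another on that chain carbon; the steps that involve the same position, a step that the two limits leave unreadable from compound 1 to compound 3 and an at least 1.4-fold higher number from compound 2 to compound 3 (0.16 log units; that floor lies within the scatter), give no readable size. The change from compound 3 to compound 4 is therefore expected to give no step beyond the scatter in this assay, with compound 4 expected to sit near the limit again. Compound 4 is estimated at 1000000 nM, between 300000 nM and 3000000 nM. The expected step is a number no higher from compound 3 to compound 4 (the limit leaves the size open).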

Compound 4, half-maximal inhibitory concentration: 189000 nM
For compound 4 the middle estimate is 5.3-fold (0.72 log units) above the measured one, and the stated range ends above it.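

In this assay, among the compounds shown here, the group on the saturated chain carbon bound to a nitrogen on an aromatic ring now shows a readable effect: furan-2-yl in place of 4-methylphenyl gives an at least 5.2-fold lower number from compound 3 to compound 4 (0.72 log units; beyond the scatter), the first step at this position that lies beyond the scatter. For the compounds shown here, the ((furan-2-yl)methyl)amino arm also stands apart from the other amino groups, since replacing pyrrolidin-1-yl gives a 3.6-fold lower number from compound 2 to compound 4 (0.56 log units; beyond the scatter), the one step here with a number at both ends, and furan-2-yl in place of hydrogen on the chain carbon gives an at least 5.2-fold lower number from compound 1 to compound 4 (0.72 log units; beyond the scatter), which leaves compound 4 with the lowest number of the four compounds. The steps starting from compound 1 and compound 3 are only floors, and the step joining those two compounds cannot be read, because both compounds sit at a limit: the limit of > 1000000 nM in this assay, at which 2 of the 4 values shown sit.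

On these data alone, it remains open whether the lower number belongs to furan-2-yl itself or to the loss of 4-methylphenyl, a question that a plain phenyl, thiophen-2-yl or pyridin-2-yl group on the same chain carbon would help settle. Also open, as far as these compounds go, is whether a longer chain carrying furan-2-yl on the amino nitrogen would keep the lower number.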